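Cyclohexyl in Place of a tert-Butyl Ester Chain

A few compounds are considered here, and "the series" means these few. Any claim that something is new, unique, unknown or untested is made for them only; others in the source may bear on it.

Compound 1 `CCCC(C)Nc1oc2c(C)ncc(CO)c2c1Nc1ccccn1` gives 9010 nM in a functional assay on HEK293 cells for agonist activity at Toll-like receptor 8 (Homo sapiens), read by reporter gene assay; a higher number here means that more compound is needed for the effect, a lower number that less compound is needed.
Compound 2 `Cc1ncc(CO)c2c(Nc3ccccn3)c(NCCC(=O)OC(C)(C)C)oc12` gives 7640 nM in this assay.

Going by the values given here, compound 2 stands beside compound 1, the only other measured compound, and the step of a 1.2-fold lower number from compound 1 to compound 2 (0.07 log units; within the scatter) is within the scatter. Compound 3 `Cc1ncc(CO)c2c(Nc3ccccn3)c(NC3CCCCC3)oc12` differs from compound 2 by cyclohexyl in place of 2-(tert-butoxycarbonyl)ethyl on a nitrogen on an aromatic ring. Among the compounds with values here, only the step of a 1.2-fold lower number from compound 1 to compound 2 (0.07 log units; within the scatter) bears on this change, another swap of the substituent on the same nitrogen, and it showed no movement beyond the scatter. The step to compound 3 is therefore expected as a 1.0-fold higher number from compound 2 to compound 3 (0.02 log units; within the scatter), none beyond the scatter. For compound 3 the estimate in this assay is 8000 nM, in the range 3000 nM to 20000 nM.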

Compound 3, half-maximal effective concentration: 6930 nM
Estimate against measurement, compound 3: 1.2-fold (0.06 log units) above, and the stated range covers the measured number.
By their numbers in this assay, from the lowest: compounds 3, 2 and 1 (each within the scatter of the next).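

In this assay, cyclohexyl on the nitrogen brings a non-aromatic ring to this position, and the number stays within the scatter, with a 1.1-fold lower number from compound 2 to compound 3 (0.04 log units; within the scatter) and a 1.3-fold lower number from compound 1 to compound 3 (0.11 log units; within the scatter). Across the three compounds shown, a ring, a branched chain and a chain ending in a tert-butyl ester therefore read alike on this nitrogen. No evidence at hand accounts for this.

Going by these compounds, whether a terminal amine or a free carboxylic acid on this nitrogen would move the number beyond the scatter remains open. So does the effect of a phenyl ring there.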